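Methyl Removed from Compound 3: Expected Cytotoxicity of Compound 4

The compounds below may be only part of what the source reports. "The series", "measured", "known", "first", "only" and "open" are said of these compounds alone.

Of the compounds shown here, three sharing one core have been tested in an ADME assay on Vero cells (Chlorocebus sabaeus) for cytotoxicity, read by WST assay; on this read-out lower numbers stand for higher toxicity in this test and higher numbers for lower toxicity in this test. Compound 1 `O=c1[nH]c(Nc2ccc(F)cc2)nc2cc(Cl)ccc12` gives > 25000 nM, which is a limit of the assay rather than a number. Compound 2 `O=c1[nH]c(Nc2ccc(Cl)cc2Cl)nc2cc(Cl)ccc12` likewise gives > 25000 nM, again only a limit. Compound 3 `COc1cccc2nc(Nc3cc(Cl)cc(Cl)c3)[nH]c(=O)c12` gives > 25000 nM, also a limit. Compound 3 therefore stands where every value shown stands, at the limit of > 25000 nM in this assay, at which 3 of the 3 values shown sit, and no measured number separates it from compound 1 or compound 2. For the measured compounds named here, no step between measured compounds can be given, since no two of them differ in one place only.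

The compound still to be measured, compound 4 `O=c1[nH]c(Nc2cc(Cl)cc(Cl)c2)nc2cccc(O)c12`, differs from compound 3 by hydrogen in place of methyl on an oxygen on an aromatic ring; cut one bond further out, the change reads methoxy to hydroxy. Going by the values given here, with all three measured values sitting at the limit, there is no measured step on which to size an expectation in this assay. The step expected for this assay is a step that the limit leaves unreadable from compound 3 to compound 4, none beyond the scatter. Compound 4 is accordingly estimated at 30000 nM, within 10000 nM to 100000 nM, and most likely reported once more as a limit.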

Compound 4, half-maximal cytotoxic concentration: > 25000 nM
Compound 4 gave a limit, no number; the forecaster's own chance of this, stated with the estimate: 80%; the middle value lies beyond the limit too.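

In this assay compound 4 gives > 25000 nM, which is again a limit and not a number. Compound 3 also stands at a limit, so no step can be read between compound 3 and compound 4: the limit of > 25000 nM in this assay, at which 4 of the 4 values shown sit. The compounds shown leave open how far beyond that limit any of them lies, and whether methoxy to hydroxy changes the read-out at all.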